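This account rests on a few compounds, and the source may have more. Where it says the series, first, only, none or still open, it means among the compounds named here.

Among the measured compounds shown here, compound 1 `Cc1nc(-c2ccccc2)c(C(=O)N2CCN(c3cccc(C(N)=O)c3)CC2)o1` is the only member of the series with a numerical result: in a functional assay on HL-60 cells (Homo sapiens) for inhibition, read by MTT assay, with a stated time of 72 h (on this read-out lower numbers stand for stronger inhibition and higher numbers for weaker inhibition), compound 1 gives 71 nM. Compound 2 `Cc1nc(-c2ccc(F)cc2)c(C(=O)N2CCN(c3ccc(Cl)cc3)CC2)o1` was also tested, and in this assay compound 2 gives "not active" (no number reported), so no single number is available for comparison. Compound 3 `Cc1nc(-c2ccccc2)c(C(=O)N2CCN(c3ccccc3F)CC2)o1` has not been measured; it differs from compound 1 in one place: 2-fluorophenyl in place of 3-carbamoylphenyl on an amine nitrogen in a ring. For the measured compounds named here, no step between two measured compounds gauges this change. The expected step is a 7.0-fold higher number from compound 1 to compound 3 (0.85 log units; beyond the scatter), toward weaker inhibition and beyond the usual scatter. Compound 3 is estimated at 500 nM in this assay, within 100 nM to 5000 nM.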

Compound 3, half-maximal inhibitory concentration: 147 nM
The estimate for compound 3 lay 3.4-fold (0.53 log units) above the measured number, and the stated range covers the measured number.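

Setting 2-fluorophenyl in place of 3-carbamoylphenyl on the amine nitrogen in the ring gives a 2.1-fold higher number from compound 1 to compound 3 (0.32 log units; beyond the scatter) in this assay, a modest step toward weaker inhibition. Compound 3 thus keeps a numerical result with a group that has no hydrogen-bond donors or acceptors, so 3-carbamoylphenyl is not required for a number at this position. Nothing available explains the size of this step.

Open, on these data alone, is how much of the step belongs to losing the carbamoyl group and how much to adding fluorine. A plain phenyl, a nitrile or a carboxylic acid at this place would help to separate the two.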